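From ethoxycarbonyl to carboxy: compound 2 to compound 4

This account rests on a few compounds, and the source may have more. Where it says the series, first, only, none or still open, it means among the compounds named here.

Measured so far in a functional assay on ECV-304 cells (Homo sapiens) for cytotoxicity, read by MTT assay, with stated times of 24 h and 12 h (on this read-out higher numbers stand for an effect only at larger amounts of compound and lower numbers for an effect already at smaller amounts), are these compounds:
- compound 1 `CCOC(=O)/C=C/c1ccccc1OCc1nc(C)c(C)nc1C` gives 1540000 nM in this series
- compound 2 `CCOC(=O)/C=C/c1cc(Cl)ccc1OCc1nc(C)c(C)nc1C` gives 16900000 nM in this series
- compound 3 `Cc1nc(C)c(COc2ccc(/C=C/C(=O)O)cc2O)nc1C` gives 46000 nM in this series

Compound 2 holds the highest of the three numbers, and compound 1 is its nearest neighbour, with compound 3 furthest away. The next compound is compound 4 `Cc1nc(C)c(COc2ccc(Cl)cc2/C=C/C(=O)O)nc1C`, with hydrogen in place of ethyl on an oxygen next to a carbonyl group, which also reads ethoxycarbonyl to carboxy.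

Within the data shown here, no measured step covers this change. Among the measured compounds shown here, the only one, an 11-fold higher number from compound 1 to compound 2 (1.04 log units; beyond the scatter), is large but concerns chloro in place of hydrogen on an aromatic carbon, so it shows only that a single change here can move this assay well beyond the scatter. For the measured compounds named here, compound 3 at 46000 nM is the only measured compound with a 2-carboxyethenyl group, and it also differs from compound 2 elsewhere, so it suggests a direction and no exact size. A large step to a lower number is therefore expected.

The estimate is a 17-fold lower number from compound 2 to compound 4 (1.23 log units; beyond the scatter) as the expected step. For compound 4 the expected value is 1000000 nM as an estimate, with 60000 nM and 12000000 nM as the expected ends of its range.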

Compound 4, half-maximal effective concentration: 9310000 nM
The estimate for compound 4 lay 9.3-fold (0.97 log units) below the measured number; measured number inside the range.
By their numbers in this assay, from the lowest: compound 3; then compound 1; then compounds 4 and 2 (each within the scatter of the next).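

In this assay, among these compounds, the first reading of hydrogen in place of ethyl on an oxygen next to a carbonyl group is a 1.8-fold lower number from compound 2 to compound 4 (0.26 log units; within the scatter). Among the compounds shown here, with chloro on the aromatic ring, ethoxycarbonyl and carboxy therefore cannot be told apart at this place, and the large shift seen for the chloro change has no counterpart here. Compound 3 also carries the 2-carboxyethenyl group but differs from compound 4 elsewhere as well, so compound 3 at 46000 nM cannot be set against this step, and nothing at hand explains why the change leaves the number within the scatter.

From the compounds shown here alone, it remains open whether ethoxycarbonyl to carboxy reads the same on compound 1, which has hydrogen where compound 2 has chloro, so this result holds for the chloro-bearing pair only. Also open, going by these compounds, is whether a longer chain such as butyl on the same oxygen, or an amide in place of the ethyl ester, would move the number in this assay beyond the scatter.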